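Working notes: replacing the isopropyl on oxygen in compound 3

The compounds below may be only part of what the source reports. "The series", "measured", "known", "first", "only" and "open" are said of these compounds alone.

For the measured compounds named here, in a functional assay on a cell-free system (plasma, Oryctolagus cuniculus) for inhibition, with stated times of 5 min, 1 min and 6 min (a higher number here means a weaker inhibitor, a lower number a stronger inhibitor), compound 3 `CCOC(=O)c1c(C)nc(-c2cccc(C#N)c2)n1OC(C)C` gives 6740 nM, the lowest number so far. Compound 1 `CCOC(=O)c1c(C)nc(-c2cccc(C#N)c2)n1O` gives 17600 nM. Compound 2 `CCOC(=O)c1[nH]c(-c2cccc(C#N)c2)nc1C` reads > 30000 nM, which is a limit of the assay.

Compound 4 `CCOC(=O)COn1c(-c2cccc(C#N)c2)nc(C)c1C(=O)OCC` has (ethoxycarbonyl)methyl in place of isopropyl on an oxygen on an aromatic ring. The steps bearing on this are a 2.6-fold lower number from compound 1 to compound 3 (0.42 log units; beyond the scatter) and an at least 4.4-fold lower number from compound 2 to compound 3 (0.64 log units; beyond the scatter), both modest in size, while an at least 1.7-fold higher number from compound 1 to compound 2 (0.23 log units; that floor lies within the scatter) adds little. None of them tests a chain carrying an ester, so no direction is favoured. The expected outcome in this assay is a 1.2-fold higher number from compound 3 to compound 4 (0.07 log units; within the scatter), no change beyond the scatter. Compound 4 is estimated at 8000 nM, with an expected range of 2500 nM to 25000 nM.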

Compound 4, half-maximal inhibitory concentration: 6800 nM
Compound 4: the middle estimate sits 1.2-fold (0.07 log units) above what was measured; the range from low to high includes it.
By their numbers in this assay, from the lowest: compounds 3 and 4 (each within the scatter of the next); then compound 1. At a limit, above all of these: compound 2.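

In this assay, the oxygen on the aromatic ring carries a chain with an ester as readily as a plain isopropyl: a 1.0-fold higher number from compound 3 to compound 4 (0.00 log units; within the scatter). The step from the free hydroxy holds with this chain too: a 2.6-fold lower number from compound 1 to compound 4 (0.41 log units; beyond the scatter). Compound 2 reads at a limit of the assay, so an at least 4.4-fold lower number from compound 2 to compound 4 (0.64 log units; beyond the scatter) stands only as a floor: the limit of > 30000 nM in this assay, at which 1 of the 4 values shown sits.

From the compounds shown here alone, whether the carboxylic acid in place of this ester, an amine or a longer chain on this oxygen would move the number beyond the scatter stays open. So far, only isopropyl and (ethoxycarbonyl)methyl are compared here.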